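A few compounds are considered here, and "the series" means these few. Any claim that something is new, unique, unknown or untested is made for them only; others in the source may bear on it.

Measured compounds:
Compound 1 `C/C(=N\NC(=O)c1cccc(S(=O)(=O)N2CCOCC2)c1)c1cccc(N)c1` — in a functional assay on MGC-803 cells (Homo sapiens) for antiproliferative activity, read by MTT assay, with a stated time of 72 h (a lower number here means a stronger inhibitor, a higher number a weaker inhibitor), compound 1 gives > 100000 nM, which is a limit of the assay and not a number.
Compound 2 `C/C(=N\NC(=O)c1cccc(S(=O)(=O)N2CCOCC2)c1)c1ccc(F)cc1` — in this assay compound 2 gives > 100000 nM, again a limit of the assay rather than a number.

Going by the values given here, compound 2 therefore stands only at a limit, and the one other value shown is a limit too (the limit of > 100000 nM in this assay, at which 2 of the 2 values shown sit). The step that the two limits leave unreadable from compound 1 to compound 2 is accordingly unreadable. Compound 3 `C/C(=N\NC(=O)c1cccc(S(=O)(=O)N2CCOCC2)c1)c1ccccc1O` differs from compound 2 by 2-hydroxyphenyl in place of 4-fluorophenyl on a carbon with a double bond to nitrogen. Among the compounds with values here, no measured step with a readable size bears on this change, so there is no basis for expecting a readable step in this assay in either direction. Compound 3 is expected to sit near the same limit, with an estimated value of 100000 nM and a range from 30000 nM to 300000 nM. The estimated step of a number no higher from compound 2 to compound 3 (the limit leaves the size open) is thus expected to be none beyond the scatter.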

Compound 3, half-maximal inhibitory concentration: 1220 nM
The estimate for compound 3 lay 82-fold (1.91 log units) above the measured number, and the stated range ends above it.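

The group on the carbon with a double bond to nitrogen can decide whether this assay gives a readable value at all: 2-hydroxyphenyl in place of 4-fluorophenyl brings an at least 81-fold lower number from compound 2 to compound 3 (1.91 log units; beyond the scatter), and 2-hydroxyphenyl in place of 3-aminophenyl brings an at least 81-fold lower number from compound 1 to compound 3 (1.91 log units; beyond the scatter). Both groups in the first change have 7 heavy atoms and one six-membered aromatic ring of carbon only, but 2-hydroxyphenyl carries 1 hydrogen-bond donor and 1 hydrogen-bond acceptor where 4-fluorophenyl carries neither. The step between compound 1 and compound 2 cannot be read, because each of these compounds stands at a limit and not at a number: the limit of > 100000 nM in this assay, at which 2 of the 3 values shown sit.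

The compounds shown leave open whether the gain follows the hydroxyl itself or its place on the ring. A 4-hydroxyphenyl, 2-methoxyphenyl or 2-aminophenyl group at this position would help to separate these possibilities.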